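The source may report more compounds than this note shows. Statements on the series, on what has been measured and on what is new or still open speak of the compounds shown alone.

Measured in an ADME assay on microsomes from liver (Canis lupus familiaris) for metabolic stability, read by LC-MS, using NADPH, with a stated time of 10 min, tested at 0.1 uM; on this read-out higher numbers stand for fast clearance and lower numbers for slow clearance:
- Compound 1 `O=C(NCCCCc1ccccc1)c1cccc(C2SCC(=O)N2c2ccccn2)c1`: 492 mL.min-1.g-1
- Compound 2 `C#Cc1cccc(N2C(=O)CSC2c2cccc(C(=O)NCCCCc3ccccc3)c2)c1`: 973 mL.min-1.g-1
- Compound 3 `O=C(NCCCCn1cccn1)c1cccc(C2SCC(=O)N2c2cc(F)ccn2)c1`: 68.2 mL.min-1.g-1

Compound 2, at 973 mL.min-1.g-1, lies within the scatter of compound 1, while compound 3 gives 68.2 mL.min-1.g-1, and its gap down from compound 2 lies beyond the scatter. Compound 4 `O=C(NCCCCc1ccccc1)c1cccc(C2SCC(=O)N2c2ccc(C3CC3)cc2)c1` carries 4-cyclopropylphenyl in place of 3-ethynylphenyl on an amide-type nitrogen in a ring. For the measured compounds named here, one measured step bears on this place, a 2.0-fold higher number from compound 1 to compound 2 (0.30 log units; within the scatter), where 3-ethynylphenyl replaced pyridin-2-yl. That step stayed within the scatter, so no change beyond the scatter is expected in this assay. The expected result is a 1.1-fold lower number from compound 2 to compound 4 (0.06 log units; within the scatter). The estimated value for compound 4 is 850 mL.min-1.g-1, with an expected range of 400 mL.min-1.g-1 to 1900 mL.min-1.g-1.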

Compound 4, intrinsic clearance in microsomes: 1080 mL.min-1.g-1
The estimate for compound 4 lay 1.3-fold (0.10 log units) below the measured number; the range from low to high includes it.
By their numbers in this assay, from the lowest: compound 3; then compounds 1, 2 and 4 (each within the scatter of the next, the first and the last beyond it).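

In this assay, 4-cyclopropylphenyl in place of 3-ethynylphenyl gave a 1.1-fold higher number from compound 2 to compound 4 (0.05 log units; within the scatter), so exchanging one carbon-only phenyl group for another at this position on the amide-type nitrogen left the number unchanged within the scatter. Against pyridin-2-yl, however, 4-cyclopropylphenyl gave a 2.2-fold higher number from compound 1 to compound 4 (0.34 log units; beyond the scatter), a modest step and the first at this position to pass beyond the scatter. Nothing measured here accounts for either step. Left open is whether a phenyl group bearing an amine or a carboxylic acid at this position would stay within the scatter of compound 4. Also open, on these data alone, is whether these steps would hold with a shorter chain on the amide.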